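Bromo for Fluoro on the Core of Compound 3

A few compounds are considered here, and "the series" means these few. Any claim that something is new, unique, unknown or untested is made for them only; others in the source may bear on it.

Compound 1 `CCOC(=O)CSc1nc2cc(-n3nc(C(C)(C)C)sc3=O)c(F)cc2s1`, compound 2 `CCCOC(=O)CSc1nc2cc(-n3nc(C(C)(C)C)sc3=O)c(F)cc2s1` and compound 3 `CCOC(=O)CCSc1nc2cc(-n3nc(C(C)(C)C)sc3=O)c(F)cc2s1` share one core and differ only in the ester-bearing chain on sulfur. In an assay on isolated protein for inhibition of protoporphyrinogen oxidase (Homo sapiens), read by capillary electrophoresis (on this read-out lower numbers stand for stronger inhibition and higher numbers for weaker inhibition), compound 1 gives 340 nM, compound 2 gives 1310 nM and compound 3 gives 9260 nM, the highest of the three numbers: a 27-fold higher number from compound 1 to compound 3 (1.44 log units; beyond the scatter) and a 7.1-fold higher number from compound 2 to compound 3 (0.85 log units; beyond the scatter). Compound 4 `CCOC(=O)CCSc1nc2cc(-n3nc(C(C)(C)C)sc3=O)c(Br)cc2s1` differs from compound 3 by bromo in place of fluoro on an aromatic carbon. Among the measured compounds shown here, none of the measured steps, a 3.9-fold higher number from compound 1 to compound 2 (0.59 log units; beyond the scatter) included, touches this position; all of them concern the chain on sulfur, so no basis exists for a directed expectation. For compound 4 the expected step of a 1.0-fold lower number from compound 3 to compound 4 (0.01 log units; within the scatter) lies within the scatter. Compound 4 is estimated at 9000 nM in this assay, with a range from 3000 nM to 27000 nM.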

Compound 4, inhibition constant: 27500 nM
Beside the measured number, compound 4's estimate is 3.1-fold (0.49 log units) below it; measured number above the stated range.
By their numbers in this assay, from the lowest: compound 1; then compound 2; then compound 3; then compound 4.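

Among the compounds shown here, at the aromatic carbon ortho to a large group, which no earlier step touched, bromo in place of fluoro gives a 3.0-fold higher number from compound 3 to compound 4 (0.47 log units; beyond the scatter) in this assay. The shared core can therefore shift the number as well as the chain on sulfur, though this step is smaller than a 27-fold higher number from compound 1 to compound 3 (1.44 log units; beyond the scatter). Nothing available explains the change.

From the compounds shown here alone, it remains open how chloro, methyl or hydrogen at this position would read, and whether bromo in place of fluoro gives a similar step on compound 1 with its different chain.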